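A Thiol in Place of Methylthio on a Shared Core

This account rests on a few compounds, and the source may have more. Where it says the series, first, only, none or still open, it means among the compounds named here.

Compound 1 `COc1ccc(CNc2nc([SeH])nc3ccccc23)cc1`: > 100000 nM (a limit of the assay)
Compound 2 `COc1ccc(CNc2nc(SC)nc3ccccc23)cc1`: 93700 nM

Going by the values given here, in a functional assay on CCRF-CEM cells (Homo sapiens) for cytotoxicity, read by MTT assay, with a stated time of 72 h (a higher number here means a weaker inhibitor of growth, a lower number a stronger inhibitor of growth), compound 2 gives the only number measured so far, 93700 nM. Compound 1 reaches only the limit of the assay, > 100000 nM. Among the compounds with values here, the single measured step, an at least 1.0-fold lower number from compound 1 to compound 2 (0.02 log units; that floor lies within the scatter), sits at the floor set by the limit of > 100000 nM in this assay, at which 1 of the 2 values shown sits. Compound 3 `COc1ccc(CNc2nc(S)nc3ccccc23)cc1` differs from compound 2 by hydrogen in place of methyl on a sulfur. Within the data shown here, only that one step bears on this change, and it was no larger than the scatter, so for compound 3 no shift beyond the scatter is expected, a 1.1-fold higher number from compound 2 to compound 3 (0.03 log units; within the scatter). Compound 3 is therefore estimated at 100000 nM, within 40000 nM to 250000 nM, with a fair chance that only a limit is reported.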

Compound 3, concentration for 50% growth inhibition: 10400 nM
For compound 3 the middle estimate is 9.6-fold (0.98 log units) above the measured one; measured number below the stated range.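

In this assay the sulfur substituent does matter: there is a 9.0-fold lower number from compound 2 to compound 3 (0.95 log units; beyond the scatter) when hydrogen replaces methyl on a sulfur, something the earlier step, stuck at its floor, could not reveal. Sulfur in place of selenium on the aromatic carbon also gives an at least 9.6-fold lower number from compound 1 to compound 3 (0.98 log units; beyond the scatter) but only a floor can be read for that step, and it rests on a limit: the limit of > 100000 nM in this assay, at which 1 of the 3 values shown sits.

The compounds shown leave open whether an ethyl group or a longer chain on this sulfur behaves like methyl. They also leave open how an amine in place of the sulfanyl group would compare with compound 3.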